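A few compounds are considered here, and "the series" means these few. Any claim that something is new, unique, unknown or untested is made for them only; others in the source may bear on it.

Measured so far in a functional assay on MIA PaCa-2 cells (Homo sapiens) for inhibition; on this read-out lower numbers stand for stronger inhibition and higher numbers for weaker inhibition:
- compound 1 `CCC(C)C(NC(=O)NO)C(=O)NC1CCCCC1`: > 100000 nM, a limit of the assay
- compound 2 `CC(C)C(NC(=O)NO)C(=O)NC1CCCC1`: > 100000 nM, a limit of the assay

Compound 2 stands at the limit of this assay and has no number of its own. Compound 1 likewise sits at that limit. Together the two values make up (the limit of > 100000 nM in this assay, at which 2 of the 2 values shown sit), so no step between measured compounds can be computed and no order between compound 1 and compound 2 can be stated.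

Compound 3 `CCC(C)C(NC(=O)NO)C(=O)NC1CCCC1` is not yet measured. It differs from compound 2 by methyl in place of hydrogen on a saturated chain carbon, three bonds along the chain from an amide-type nitrogen and a carbonyl carbon; cut one bond further out, the change reads methyl to ethyl, isopropyl to sec-butyl. For the measured compounds named here, no measured pair isolates this change. Compound 1 already carries the sec-butyl group, and its value in this assay is a limit, > 100000 nM. Because the limit of > 100000 nM in this assay, at which 2 of the 2 values shown sit, covers every value shown, the step from compound 2 to compound 3 is expected to be a number no higher from compound 2 to compound 3 (the limit leaves the size open), none beyond the scatter. Compound 3 is expected to give 100000 nM, within 30000 nM to 300000 nM, most likely reported again only as a limit.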

Compound 3, half-maximal inhibitory concentration: > 100000 nM
Compound 3 was reported as a limit (the forecaster's own chance of this, stated with the estimate: 85%); the middle value sits exactly at the limit.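

The steps linking compound 3 to compound 2 and to compound 1 cannot be read, because all three compounds give only a limit: the limit of > 100000 nM in this assay, at which 3 of the 3 values shown sit.

The compounds shown leave open whether swapping hydrogen for methyl or cyclohexyl for cyclopentyl changes anything in this assay, and at what concentration any of the three compounds would inhibit.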